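Aryl swap on the shared core of compound 2

The source may hold more compounds than are shown below. What is called first, only, known or untested is meant among the compounds shown, and "the series" means these compounds.

Within the data shown here, compound 2 `CC(C)c1cccc(C(C)C)c1NC(=O)NCC1(c2ccc(C(C)(C)C)cc2)CCCC1` gives 63 nM in an assay on microsomes for inhibition of acyl-CoA:cholesterol acyltransferase (Oryctolagus cuniculus) (a higher number here means a weaker inhibitor, a lower number a stronger inhibitor), the higher of the two numbers known, yet compound 1 `CC(C)c1ccc(C2(CNC(=O)Nc3c(C(C)C)cccc3C(C)C)CCCC2)cc1` gives 48 nM in this assay, and the single measured step, a 1.3-fold higher number from compound 1 to compound 2 (0.12 log units; within the scatter), lies within the scatter. Compound 3 `COc1cccc(C2(CNC(=O)Nc3c(C(C)C)cccc3C(C)C)CCCC2)c1` carries a different change: 3-methoxyphenyl in place of 4-(tert-butyl)phenyl on a saturated ring carbon. Among the measured compounds shown here, no measured step bears on this exchange of aryl groups, so no direction is anchored. Compound 3 is therefore expected to give about 150 nM in this assay, within a wide range from 40 nM to 600 nM. The expected step is a 2.4-fold higher number from compound 2 to compound 3 (0.38 log units; beyond the scatter).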

Compound 3, half-maximal inhibitory concentration: 13 nM
For compound 3 the middle estimate is 12-fold (1.06 log units) above the measured one; the measured number lies below the stated range.
By their numbers in this assay, from the lowest: compound 3; then compounds 1 and 2 (each within the scatter of the next).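

On the saturated ring carbon, the identity of the aryl group moves the number in this assay beyond the scatter, which the alkyl exchange between compounds 1 and 2 did not show. Placing 3-methoxyphenyl there gives a 4.8-fold lower number from compound 2 to compound 3 (0.69 log units; beyond the scatter) and, against 4-isopropylphenyl, a 3.7-fold lower number from compound 1 to compound 3 (0.57 log units; beyond the scatter) so both alkyl-bearing aryl groups are left behind by a similar margin. No measurement on hand accounts for this difference.

The compounds shown leave open whether the methoxy group itself carries the difference, and how a hydroxy group or a chlorine atom in its place would read.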